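The source may hold more compounds than are shown below. What is called first, only, known or untested is meant among the compounds shown, and "the series" means these compounds.

Working notes on the sulfone series.

Compound 1 `COc1ccc(CS(=O)(=O)CC(=O)Nc2c(C)cc(C)cc2C)cc1[N+](=O)[O-]` is the reference point; in a functional assay on HCT-116 cells (Homo sapiens) for cytotoxicity, read by MTT assay, with a stated time of 72 h (a lower number here means a stronger inhibitor of growth, a higher number a weaker inhibitor of growth), compound 1 gives 7910 nM. Compound 3 `COc1ccc(CS(=O)(=O)CC(=O)Nc2c(C)cc(C)cc2C)cc1N` differs from it by one change, (amino in place of nitro on an aromatic carbon). For compound 3 the readout in this assay is a limit of the assay, > 30000 nM, not a number. The step is therefore also bounded: an at least 3.7-fold higher number from compound 1 to compound 3 (0.57 log units; beyond the scatter). Whatever lies behind this loss is not measured here; the only context is the limit of > 30000 nM in this assay, at which 2 of the 3 values shown sit.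

Compound 2 `COc1cc(/C=C/S(=O)(=O)Cc2ccc(OC)c([N+](=O)[O-])c2)cc(OC)c1` carries a different core from compound 1, and the difference between the two cores is not broken down here. In this assay compound 2 reaches only a limit of the assay, > 30000 nM.

Compound 4 `COc1cc(/C=C/S(=O)(=O)Cc2ccc(OC)c(N)c2)cc(OC)c1` stands to compound 2 exactly as compound 3 stands to compound 1: the change is amino in place of nitro on an aromatic carbon, and the place lines of the two changes read the same word for word, so it is the same change made on the second core.

Expectation for compound 4 in this assay. Among the measured compounds shown here, compound 2 is already at the limit, and the one measured instance of this change, from compound 1 to compound 3, moved the value upward by an at least 3.7-fold higher number from compound 1 to compound 3 (0.57 log units; beyond the scatter). On that basis compound 4 is expected to remain at or beyond the limit, with the expected step that the limit leaves unreadable from compound 2 to compound 4. The estimate for compound 4 in this assay is 70000 nM, expected to fall between 30000 nM and 300000 nM, with a high chance that only a limit is reported.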

Compound 4, concentration for 50% growth inhibition: 540 nM
The estimate for compound 4 lay 130-fold (2.11 log units) above the measured number; measured number below the stated range.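

In this assay, amino in place of nitro on an aromatic carbon gives an at least 55-fold lower number from compound 2 to compound 4 (1.74 log units; beyond the scatter), so on this core the change runs the opposite way to the one measured on the core of compound 1, and the two steps do not agree: the same change on two cores in this assay, an at least 3.7-fold higher number (0.57 log units; beyond the scatter) from compound 1 to compound 3 and an at least 55-fold lower number (1.74 log units; beyond the scatter) from compound 2 to compound 4, at least 210-fold (2.32 log units) apart, beyond the scatter of two such steps. The outcome of this change therefore does not carry from the core of compound 1 to the core of compound 2, not even in direction, although only these two cores are compared. It remains unshown which part of the cores goes with the reversal, and each step is known only as a bound, since each has a limit of the assay at one end: the limit of > 30000 nM in this assay, at which 2 of the 4 values shown sit.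

The compounds shown leave open whether the amino group itself is needed on the core of compound 4, or whether a hydroxyl, an acetamide or a dimethylamino group in the same place would hold the value of compound 4, 540 nM. They also leave open whether a third core would follow the pair of compound 1 and compound 3 or the pair of compound 2 and compound 4.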